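The source may report more compounds than this note shows. Statements on the series, on what has been measured and on what is new or still open speak of the compounds shown alone.

Compound 1 `N#Cc1cc(Cl)cc(Oc2cc(OCc3noc4nc(-n5ccnc5)ccc34)ccc2Cl)c1`: 1.7 h
Compound 2 `N#Cc1cc(Cl)cc(Oc2cc(OCc3n[nH]c4ncccc34)cc(Cl)c2Cl)c1`: 9.4 h
Compound 3 `N#Cc1cc(Cl)cc(Oc2cc(OCc3n[nH]c4nc(N)ccc34)cc(F)c2Cl)c1`: 4.6 h

In an in vivo ADME assay on the whole organism (strain Sprague-Dawley) for metabolic stability, with Rattus norvegicus as the target, at a dose of 2 mg/kg by the intravenous route (a lower number here means that the compound disappears faster, a higher number that the compound lasts longer), compound 1 stands lowest of the three, and the gaps to both others lie beyond the scatter. Compound 4 `CNc1ccc2c(COc3ccc(Cl)c(Oc4cc(Cl)cc(C#N)c4)c3)noc2n1` has methylamino in place of 1H-imidazol-1-yl on an aromatic carbon of compound 1: methylamino in place of 1H-imidazol-1-yl on an aromatic carbon. Among the measured compounds shown here, no two measured compounds differ in only one place, so the data offer no direct measure of this change. For the measured compounds named here, the only weak guide is that compound 1 sits at the bottom of the range, while compound 3, which has a different core, reaches 4.6 h. The expected step is a 1.5-fold higher number from compound 1 to compound 4 (0.17 log units; within the scatter), a small rise estimated to stay within the scatter. For compound 4 the estimated half-life is 2.5 h, with an expected range of 1 h to 6 h.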

Compound 4, half-life: 2 h
Beside the measured number, compound 4's estimate is 1.3-fold (0.10 log units) above it, within the range that was stated.
By their numbers in this assay, from the lowest: compounds 1 and 4 (each within the scatter of the next); then compound 3; then compound 2.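

In this assay, putting methylamino in place of 1H-imidazol-1-yl on this aromatic carbon next to the ring nitrogen gives a 1.2-fold higher number from compound 1 to compound 4 (0.07 log units; within the scatter) and this step lies within the scatter. On the core of compound 1, then, a five-membered aromatic ring can give way to a small group with no ring while the half-life stays the same within the scatter. No measurement here offers a reason for this.

From the compounds shown here alone, whether a larger group at this carbon, such as a morpholine ring or a carboxylic acid, would change the half-life remains open.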